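Phenylpropyl amide in place of the benzothiazole amide

The source may hold more compounds than are shown below. What is called first, only, known or untested is meant among the compounds shown, and "the series" means these compounds.

Measured so far:
compound 1 `CC(C)C(NS(=O)(=O)Cc1ccccc1)C(=O)N1CCC(c2ccc(Cl)cc2)CC1`: 303 nM
compound 2 `CC(C)[C@@H](NC(=O)c1nc2ccccc2s1)C(=O)N1CCC(c2ccc(Cl)cc2)CC1`: 18 nM
compound 3 `CC(C)C(NC(=O)OCc1ccccc1)C(=O)N1CCC(c2ccc(Cl)cc2)CC1`: 1080 nM

In an assay on THP-1 cells for displacement of a labelled ligand from C-C chemokine receptor type 1 (Homo sapiens) (a lower number here means a stronger inhibitor, a higher number a weaker inhibitor), compound 2 gives the lowest number of the three; compound 1 stands nearest and compound 3 furthest, both gaps beyond the scatter. For the measured compounds named here, the only single-point step, a 3.6-fold higher number from compound 1 to compound 3 (0.55 log units; beyond the scatter), concerns the group on the amine nitrogen and does not touch the part varied here. Compound 4 `CC(C)[C@@H](NC(=O)CCCc1ccccc1)C(=O)N1CCC(c2ccc(Cl)cc2)CC1` differs from compound 2 by 3-phenylpropyl in place of 1,3-benzothiazol-2-yl on a carbonyl carbon. Going by the values given here, no measured pair isolates this exchange; compounds 1 and 3 sit well above compound 2, but each differs from it in more than one respect, so they give only a loose pointer. A weakening is expected, with wide uncertainty: compound 4 is estimated at 200 nM (50 nM to 800 nM), a step of an 11-fold higher number from compound 2 to compound 4 (1.05 log units; beyond the scatter).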

Compound 4, half-maximal inhibitory concentration: 95 nM
Beside the measured number, compound 4's estimate is 2.1-fold (0.32 log units) above it, within the range that was stated.
By their numbers in this assay, from the lowest: compound 2; then compound 4; then compound 1; then compound 3.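

In this assay, for the compounds shown here, 3-phenylpropyl in place of 1,3-benzothiazol-2-yl on a carbonyl carbon gives a 5.3-fold higher number from compound 2 to compound 4 (0.72 log units; beyond the scatter), the only single-place reading at this position. The fused aromatic system with its nitrogen and sulfur is therefore favourable but not essential: with an all-carbon group ending in a phenyl ring, compound 4 still reads 95 nM. Nothing measured here accounts for the step. Still open, on these data alone, is whether a shorter phenylalkyl chain, or a 1,3-benzoxazol-2-yl group with oxygen in place of sulfur, would recover the lost strength.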